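Swapping an Aryl Sulfonyl for an Alkyl Sulfonyl

The compounds below may be only part of what the source reports. "The series", "measured", "known", "first", "only" and "open" are said of these compounds alone.

Three measured compounds share one core and differ in the group on an amine nitrogen in a ring. In an assay on isolated protein for inhibition of 5-hydroxytryptamine receptor 4 (Homo sapiens) (a higher number here means a weaker inhibitor, a lower number a stronger inhibitor), compound 1 `O=C(NCC1CCN(CCCS(=O)(=O)N2CCN(Cc3cccnc3)CC2)CC1)c1cccc2c1OCCO2` gives 0.159 nM, compound 2 `O=C(NCC1CCN(CCCS(=O)(=O)N2CCN(C3CCCC3)CC2)CC1)c1cccc2c1OCCO2` gives 0.0159 nM, and compound 3 `O=C(NCC1CCN(CCCS(=O)(=O)N2CCN(S(=O)(=O)c3ccc(F)cc3)CC2)CC1)c1cccc2c1OCCO2` gives 0.0316 nM. Compound 3 thus stands second highest of the three numbers: a 2.0-fold higher number from compound 2 to compound 3 (0.30 log units; within the scatter), while a 5.0-fold lower number from compound 1 to compound 3 (0.70 log units; beyond the scatter). Compound 4 `CC(C)S(=O)(=O)N1CCN(S(=O)(=O)CCCN2CCC(CNC(=O)c3cccc4c3OCCO4)CC2)CC1` is not yet measured and differs from compound 3 by isopropyl in place of 4-fluorophenyl on a sulfonyl sulfur. Going by the values given here, no measured step changes a group on the sulfonyl sulfur, so the closest guide is that quite different groups on the ring nitrogen in compound 2 and compound 3 gave numbers within the scatter. A small shift is therefore expected: a 1.6-fold higher number from compound 3 to compound 4 (0.20 log units; within the scatter). Compound 4 is estimated at 0.05 nM, between 0.012 nM and 0.2 nM.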

Compound 4, inhibition constant: 0.126 nM
For compound 4 the middle estimate is 2.5-fold (0.40 log units) below the measured one; the range from low to high includes it.
By their numbers in this assay, from the lowest: compounds 2 and 3 (each within the scatter of the next); then compounds 4 and 1 (each within the scatter of the next).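

The group on the sulfonyl sulfur matters in this assay: isopropyl in place of 4-fluorophenyl gives a 4.0-fold higher number from compound 3 to compound 4 (0.60 log units; beyond the scatter), a real change where the earlier swap of ring-nitrogen groups stayed within the scatter. Isopropylsulfonyl also gives a 7.9-fold higher number from compound 2 to compound 4 (0.90 log units; beyond the scatter), whereas it gives only a 1.3-fold lower number from compound 1 to compound 4 (0.10 log units; within the scatter), so it offers no real gain over (pyridin-3-yl)methyl. Nothing available explains these steps. Going by these compounds, whether a plain phenyl, a cyclopropyl or a tert-butyl on the same sulfonyl sulfur would fall nearer compound 3 or compound 4 stays open.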